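Compound 3: A Carboxymethyl Analogue Awaiting the Inhibition Assay

The source may report more compounds than this note shows. Statements on the series, on what has been measured and on what is new or still open speak of the compounds shown alone.

Of the compounds shown here, two sharing one core have been measured in a functional assay on the whole organism for inhibition, with Rattus norvegicus as the target; on this read-out lower numbers stand for an effect already at smaller amounts and higher numbers for an effect only at larger amounts of compound. Compound 1 `CC1CC/C(=N\Nc2ccc(C(=O)O)cc2)c2ncc(C(=O)O)c(=O)n21` gives 7.6 umol/kg there. Compound 2 `CCCCc1ccc(N/N=C2\CCC(C)n3c2ncc(C(=O)O)c3=O)cc1` gives 7.8 umol/kg in this assay. Compound 2 carries the higher of the two numbers, but only by a 1.0-fold higher number from compound 1 to compound 2 (0.01 log units; within the scatter), a step within the scatter, so the two compounds cannot be told apart. Compound 3 `CC1CC/C(=N\Nc2ccc(CC(=O)O)cc2)c2ncc(C(=O)O)c(=O)n21` has not yet been measured. It differs from compound 2 by carboxy in place of propyl on a saturated chain carbon bound to an aromatic carbon, a change that, read one bond further out, is butyl to carboxymethyl. Going by the values given here, the only measured step that bears on it is a 1.0-fold higher number from compound 1 to compound 2 (0.01 log units; within the scatter), where butyl in place of carboxy on the aromatic carbon left the read-out unchanged. Because a 1.0-fold higher number from compound 1 to compound 2 (0.01 log units; within the scatter) showed no movement between carboxy and butyl, compound 3 is expected to sit close to compound 2, with an expected step of a 1.0-fold lower number from compound 2 to compound 3 (0.01 log units; within the scatter) in this assay. Compound 3 is therefore estimated at 7.7 umol/kg, with a range from 3.5 umol/kg to 17 umol/kg.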

Compound 3, dose for 50% inhibition: 60.9 umol/kg
For compound 3 the middle estimate is 7.9-fold (0.90 log units) below the measured one; the whole stated range lies below it.
By their numbers in this assay, from the lowest: compounds 1 and 2 (each within the scatter of the next); then compound 3.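

In this assay the place on the aromatic carbon proves sensitive to what it carries: carboxy and butyl could not be told apart there, yet carboxymethyl in place of carboxy gives an 8.0-fold higher number from compound 1 to compound 3 (0.90 log units; beyond the scatter) in a change of a single chain carbon. Carboxy in place of propyl on a saturated chain carbon bound to an aromatic carbon gives a 7.8-fold higher number from compound 2 to compound 3 (0.89 log units; beyond the scatter) and thus separates compound 3 from both earlier compounds. So carboxy set on the chain does not read like carboxy set directly on the aromatic carbon.

The compounds shown leave open whether the shift follows from the extra chain carbon alone or from the carboxy at its end. As far as these compounds go, it also remains open whether a primary amide or a longer chain ending in carboxy would stay with compound 3 or fall in with compound 1 and compound 2. No evidence accompanies this result that would account for it.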